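This account rests on a few compounds, and the source may have more. Where it says the series, first, only, none or still open, it means among the compounds named here.

Compound 1 `C=C[C@@](C)(/C=C/c1ccc(Nc2ccc(F)c(F)c2)cc1)CCC=C(C)C` and compound 2 `C=C[C@@](C)(/C=C/c1ccc(Nc2cc(F)c(F)cc2F)cc1)CCC=C(C)C` share the same core and differ only in their fluorine-bearing ring. Both were tested in a functional assay on SEM cells (Homo sapiens) for cytotoxicity, with a stated time of 72 h; on this read-out lower numbers stand for an effect already at smaller amounts and higher numbers for an effect only at larger amounts of compound. In this assay compound 1 gives > 36600 nM, which is a limit of the assay and not a number. Compound 2 gives > 36600 nM, again only a limit. So compound 2 has no exact place on the scale, and the one other value beside it is a limit too. For the measured compounds named here, the single measured step, a step that the two limits leave unreadable from compound 1 to compound 2, therefore has no readable size.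

Compound 3 `C=C[C@@](C)(/C=C/c1ccc(Nc2cc(F)c(F)c(F)c2)cc1)CCC=C(C)C` keeps the same atoms but rearranges them: 3,4,5-trifluorophenyl in place of 2,4,5-trifluorophenyl on a nitrogen on an aromatic ring. Going by the values given here, the only guide is the limit of > 36600 nM in this assay, at which 2 of the 2 values shown sit, and no measured step shows what moving a fluorine does. The expectation therefore rests on compound 2, whose value of > 36600 nM is a limit, and no step beyond the usual scatter is foreseen, with a further limit the likeliest result. The expected size is a step that the limit leaves unreadable from compound 2 to compound 3. For compound 3 the estimated value is 40000 nM, with an expected range from 15000 nM to 70000 nM.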

Compound 3, half-maximal effective concentration: > 36600 nM
Compound 3 ended at the assay's limit (the forecaster's own chance of this, stated with the estimate: 75%); the middle value does not contradict the limit.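

In this assay compound 3 gives > 36600 nM, again a limit of the assay and not a number. The steps among compound 1, compound 2 and compound 3 therefore cannot be read, and all three share one result: the limit of > 36600 nM in this assay, at which 3 of the 3 values shown sit.

The compounds shown leave open whether adding or moving a fluorine on this ring changes the effect on these cells at all.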